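Toxicity notes on a bis-arylidene cyclohexanone series

The compounds below may be only part of what the source reports. "The series", "measured", "known", "first", "only" and "open" are said of these compounds alone.

The shared core is the bis-arylidene cyclohexanone of compound 1 `COc1ccc(/C=C2\CCC/C(=C\c3ccc(OC)cc3)C2=O)cc1`. In an ADME assay on Vero cells (Chlorocebus sabaeus) for inhibition (on this read-out lower numbers stand for higher toxicity in this test and higher numbers for lower toxicity in this test), compound 1 gives 178000 nM. Compound 2 `COc1ccc(/C=C2\CCC/C(=C\c3ccc(Br)cc3)C2=O)cc1` gives 250000 nM, and compound 3 `COc1ccc(/C=C2\CCC/C(=C\c3ccc(F)cc3)C2=O)cc1` gives 378000 nM. The step of a 1.4-fold higher number from compound 1 to compound 2 (0.15 log units; within the scatter) stays inside the scatter, whereas a 2.1-fold higher number from compound 1 to compound 3 (0.33 log units; beyond the scatter) is a modest step beyond it; between the two halogen analogues a 1.5-fold higher number from compound 2 to compound 3 (0.18 log units; within the scatter) is again within the scatter. Compound 3 therefore holds the highest number of the three, separated from compound 2 by a gap within the scatter and from compound 1 by a modest gap beyond it.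

Compound 4 `COc1ccc(/C=C2\CCC/C(=C\c3cccc(Br)c3)C2=O)cc1` differs from compound 3 by 3-bromophenyl in place of 4-fluorophenyl on a double-bonded chain carbon bound to a double-bonded ring carbon. Among the compounds with values here, the bearing step is the halogen exchange from compound 2 to compound 3, which moved the number only within the scatter; the move of the bromine to the 3-bromophenyl arrangement has no precedent here. A step of none beyond the scatter is expected for compound 4, at most a small drift back toward the number of compound 2, so the estimated step is a 1.3-fold lower number from compound 3 to compound 4 (0.12 log units; within the scatter). In this assay compound 4 is expected at 290000 nM, with a range from 150000 nM to 550000 nM.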

Compound 4, half-maximal cytotoxic concentration: 30000 nM
Beside the measured number, compound 4's estimate is 9.7-fold (0.99 log units) above it, outside the stated range (below it).
By their numbers in this assay, from the lowest: compound 4; then compounds 1, 2 and 3 (each within the scatter of the next, the first and the last beyond it).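

The 3-bromophenyl group on a double-bonded chain carbon bound to a double-bonded ring carbon opens a far wider gap in this assay than any exchange among compounds 1, 2 and 3, whose largest step is a 2.1-fold higher number from compound 1 to compound 3 (0.33 log units; beyond the scatter): the large 13-fold lower number from compound 3 to compound 4 (1.10 log units; beyond the scatter) and a 5.9-fold lower number from compound 1 to compound 4 (0.77 log units; beyond the scatter) both exceed it. The closest comparison is an 8.3-fold lower number from compound 2 to compound 4 (0.92 log units; beyond the scatter), in which 3-bromophenyl replaces 4-bromophenyl; the bromine stays in the molecule, so where it sits on the aromatic ring matters here, and this arrangement alone brings a step beyond the scatter toward higher toxicity in this test, with compound 4 lowest of the four by steps beyond the scatter to each of the others. Nothing available on these compounds accounts for this shift.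

As far as these compounds go, with a single compound carrying this arrangement, it remains open whether the drop belongs to the bromine itself or would persist with an amine or a carboxylic acid in its place on the aromatic ring. Also open, from the compounds shown here alone, is how the number would respond if a second 3-bromophenyl replaced the remaining 4-methoxyphenyl of compound 4.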